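Swapping the methoxyphenyl of compound 1 for a dichlorophenyl

The source may report more compounds than this note shows. Statements on the series, on what has been measured and on what is new or still open speak of the compounds shown alone.

Measured compounds:
- compound 1, `COc1ccc(/C=C/C(=O)Oc2ccc(/C=C3\CCCCC3=O)cc2)cc1`: 2060 nM
- compound 2, `O=C(/C=C/c1ccc(F)cc1)Oc1ccc(/C=C2\CCCCC2=O)cc1`: 26600 nM
- compound 3, `O=C(/C=C/c1ccc(Br)cc1)Oc1ccc(/C=C2\CCCCC2=O)cc1`: 180000 nM

In a functional assay on MOLT-4 cells (Homo sapiens) (a higher number here means a weaker inhibitor, a lower number a stronger inhibitor), compound 1 gives the lowest of the three numbers, so it is the strongest inhibitor of this small group. The step of a 13-fold higher number from compound 1 to compound 2 (1.11 log units; beyond the scatter) is large, and the step of an 87-fold higher number from compound 1 to compound 3 (1.94 log units; beyond the scatter) is larger still; both go to weaker inhibition. Between the two halogen compounds, a 6.8-fold higher number from compound 2 to compound 3 (0.83 log units; beyond the scatter) is modest and in the same direction.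

Compound 4, `O=C(/C=C/c1ccc(Cl)c(Cl)c1)Oc1ccc(/C=C2\CCCCC2=O)cc1`, has not been measured in this assay. It differs from compound 1 as follows: 3,4-dichlorophenyl in place of 4-methoxyphenyl on a double-bonded chain carbon bound to a double-bonded chain carbon. The measured steps that bear on this change are those where a halogen replaces the methoxy group, and each of them produced a large rise in the number. Chlorine is a halogen like fluorine and bromine, and here two chlorines enter at once, so a large step toward weaker inhibition is expected, roughly of the size seen between compound 1 and the halogen compounds. The expected step is a 39-fold higher number from compound 1 to compound 4 (1.59 log units; beyond the scatter). Compound 4 is therefore estimated at 80000 nM, with a plausible range from 20000 nM to 300000 nM.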

Compound 4, half-maximal inhibitory concentration: 47300 nM
The estimate for compound 4 lay 1.7-fold (0.23 log units) above the measured number; measured number inside the range.
By their numbers in this assay, from the lowest: compound 1; then compounds 2 and 4 (each within the scatter of the next); then compound 3.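

In this assay the 3,4-dichlorophenyl group also lands on the weak side of the 4-methoxyphenyl group, with a 23-fold higher number from compound 1 to compound 4 (1.36 log units; beyond the scatter), so a ring carrying halogen at both named positions does not recover the number of compound 1. The halogen compounds do not all sit at one level, since the change to this ring gives a 3.8-fold lower number from compound 3 to compound 4 (0.58 log units; beyond the scatter), a step beyond the scatter, while a 1.8-fold higher number from compound 2 to compound 4 (0.25 log units; within the scatter) stays within it, which leaves compound 2 and compound 4 unordered and shows that adding a second halogen does not by itself weaken inhibition further. No measurement here explains why these ring changes shift the number as they do.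

From the compounds shown here alone, it remains open whether the low number of compound 1 is specific to methoxy or would also appear with a hydroxyl, a dimethylamino group or a plain unsubstituted phenyl ring at this place. A 4-chlorophenyl compound would show how much of the step to compound 4 comes from chlorine alone and how much from the dichloro pattern.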